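The source may hold more compounds than are shown below. What is called first, only, known or untested is meant among the compounds shown, and "the series" means these compounds.

Compound 1 has the structure `CC(C)(C)Nc1nc2sc(-c3ccc(Cl)cc3)cc2c(=O)[nH]1`; in a toxicity assay on HepG2 cells (Homo sapiens) for cytotoxicity, read by MTT assay, with a stated time of 72 h (on this read-out higher numbers stand for lower toxicity in this test and lower numbers for higher toxicity in this test), compound 1 gives 21400 nM. Compound 2 has the structure `CC(C)(C)Nc1nc2sc(-c3ccc(F)cc3)cc2c(=O)[nH]1`; in this assay compound 2 gives > 25000 nM, which is a limit of the test and not a number. Compound 3 has the structure `Cc1c(-c2ccc(Cl)cc2)sc2c(=O)[nH]c(NC(C)C)nc12`; in this assay compound 3 gives > 25000 nM, again a limit and not a number.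

Going by the values given here, the one measured change, (fluoro in place of chloro on an aromatic carbon), gives an at least 1.1-fold higher number from compound 1 to compound 2 (0.06 log units; that floor lies within the scatter). That step rests on (the limit of > 25000 nM in this assay, at which 2 of the 3 values shown sit), so its true size is not known. The cores of compound 1 and compound 3 are built from the same atoms joined differently; that difference is not broken down here.

Compound 4, with the structure `Cc1c(-c2ccc(F)cc2)sc2c(=O)[nH]c(NC(C)C)nc12`, is not yet measured. It carries the same change as before: fluoro in place of chloro on an aromatic carbon, in the same place. Compound 4 is expected to stay at the limit in this assay, as compound 3 does with > 25000 nM and compound 2 with > 25000 nM. The expected step is a step that the limit leaves unreadable from compound 3 to compound 4. The estimate for compound 4 is 30000 nM, between 15000 nM and 60000 nM.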

Compound 4, half-maximal cytotoxic concentration: 19700 nM
Compound 4: the middle estimate sits 1.5-fold (0.18 log units) above what was measured; measured number inside the range.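

In this assay, the change from 4-chlorophenyl to 4-fluorophenyl gives an at least 1.2-fold lower number from compound 3 to compound 4 (0.10 log units; that floor lies within the scatter), and this figure is only a floor, not a true size. Set beside the earlier step on the other core, the comparison reads: the same change on two cores in this assay, an at least 1.1-fold higher number (0.06 log units; that floor lies within the scatter) from compound 1 to compound 2 and an at least 1.2-fold lower number (0.10 log units; that floor lies within the scatter) from compound 3 to compound 4; the limit leaves it open whether they differ. The data therefore show neither that the change carries over from one core to the other nor that its outcome depends on the core, since each step has one end that is a limit and not a number: the limit of > 25000 nM in this assay, at which 2 of the 4 values shown sit.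

The compounds shown leave open the true values of compound 2 and compound 3, and with them the size of the change on either core. They also leave open how this assay would read with a different group in the same place on the aromatic ring, such as a methoxy group, a nitrile or an amine.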